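This account rests on a few compounds, and the source may have more. Where it says the series, first, only, none or still open, it means among the compounds named here.

Values in a functional assay on MDA-MB-231 cells (Homo sapiens) for antiproliferative activity, read by CCK-8 assay, with a stated time of 48 h; on this read-out higher numbers stand for weaker inhibition and lower numbers for stronger inhibition:

- Compound 1 `O=C(/C=C/CNCCOc1ccc(Oc2c(-c3ccc(F)cc3)sc3cc(O)ccc23)cc1)N1CCCC1`: > 50000 nM (a limit)
- Compound 2 `CNC(=O)/C=C/CNCCOc1ccc(Oc2c(-c3ccc(F)cc3)sc3cc(O)ccc23)cc1`: > 50000 nM (a limit)

Compound 2 gives > 50000 nM in this assay, which is a limit of the assay and not a number. Compound 1 gives > 50000 nM, which is also a limit. The whole measured set therefore rests at the limit of > 50000 nM in this assay, at which 2 of the 2 values shown sit.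

The next compound, compound 3 `CN(C)C(=O)/C=C/CNCCOc1ccc(Oc2c(-c3ccc(F)cc3)sc3cc(O)ccc23)cc1`, changes compound 2 at its amide: methyl in place of hydrogen on an amide-type nitrogen. This is methyl in place of hydrogen on an amide-type nitrogen, so methylcarbamoyl becomes dimethylcarbamoyl.

Within the data shown here, one measured step bears on this amide: a step that the two limits leave unreadable from compound 1 to compound 2, with methylamino in place of pyrrolidin-1-yl on a carbonyl carbon. It offers no size to carry over, and neither amide shown gives a number. No change beyond the scatter is therefore expected in this assay, and another report of a limit is the likeliest outcome. The expected step is a number no higher from compound 2 to compound 3 (the limit leaves the size open). For compound 3 the estimated value is 50000 nM, with an expected range of 20000 nM to 100000 nM.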

Compound 3, half-maximal inhibitory concentration: > 50000 nM
Compound 3: only a limit was reported; the forecaster's own chance of this, stated with the estimate: 85%; the middle value sits exactly at the limit.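

In this assay compound 3 gives > 50000 nM, which is a limit of the assay and not a number. Among these compounds, no step among compound 1, compound 2 and compound 3 can be read, and the set stands thus: the limit of > 50000 nM in this assay, at which 3 of the 3 values shown sit. The compounds shown leave open whether changing the group on this amide affects the read-out at all.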